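The source may report more compounds than this note shows. Statements on the series, on what has been measured and on what is new or still open speak of the compounds shown alone.

Compound 1 `O=C1CS/C(=N\c2csc(-c3ccccc3)c2)N1`; compound 2 `COc1ccc(/C=C2\S/C(=N\c3csc(-c4ccc(Cl)cc4)c3)NC2=O)cc1`; compound 3 `Cc1ccc(/C=C2\S/C(=N\c3csc(-c4ccc(Cl)cc4)c3)NC2=O)cc1`.

Of the compounds shown here, three share one core and have been tested in a functional assay on MCF7 cells (Homo sapiens) for cytotoxicity, read by MTT assay, with a stated time of 72 h; on this read-out lower numbers stand for stronger inhibition and higher numbers for weaker inhibition. Compound 2 gives 1000 nM. Compound 3 gives 900 nM. Compound 1 gives > 50000 nM, which is a limit of the assay and not a number. Compound 3 therefore holds the lowest of the two numbers, but compound 2 sits within the scatter of it, so the two cannot be told apart.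

Compound 4 `O=C1N/C(=N/c2csc(-c3ccc(Cl)cc3)c2)S/C1=C\c1ccc(O)cc1` differs from compound 3 in one place: hydroxy in place of methyl on an aromatic carbon. Among the measured compounds shown here, only one measured step touches the same position on the same ring, namely a 1.1-fold lower number from compound 2 to compound 3 (0.05 log units; within the scatter), and it stayed within the scatter. For the measured compounds named here, with that as the sole guide, the swap to hydroxy is expected to move the number little, so for compound 4 the step of a 1.1-fold higher number from compound 3 to compound 4 (0.05 log units; within the scatter) is expected. Compound 4 is estimated at 1000 nM, with a likely range from 400 nM to 2500 nM.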

Compound 4, half-maximal inhibitory concentration: > 50000 nM
Compound 4: only a limit was reported (the forecaster's own chance of this, stated with the estimate: 5%); middle value at least 50-fold (1.69 log units) from the limit.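

In this assay, methoxy and methyl on this ring carbon could not be told apart, yet hydroxy in place of methyl gives an at least 55-fold higher number from compound 3 to compound 4 (1.74 log units; beyond the scatter). Taking only the methyl off the oxygen of the methoxy group gives an at least 50-fold higher number from compound 2 to compound 4 (1.69 log units; beyond the scatter), so compound 2 shows that an oxygen on this carbon can still give a measured number, and the hydrogen on that oxygen is the one difference that separates it from compound 4. Compound 4 has only a limit and not a number, so both steps give a minimum size and its true value stays unknown: the limit of > 50000 nM in this assay, at which 2 of the 4 values shown sit.

Still open, going by these compounds, is whether an amine or a carboxylic acid on the same ring carbon would behave like hydroxy or like methyl. Also open, on these data alone, is how a longer chain on that oxygen, such as ethoxy, would read.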